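The compounds below may be only part of what the source reports. "The series", "measured", "known", "first", "only" and "open" are said of these compounds alone.

Of the compounds shown here, three sharing one core have been tested in an ADME assay on microsomes from liver (Homo sapiens) for metabolic stability; on this read-out lower numbers stand for slow clearance and higher numbers for fast clearance. Compound 1 `CC(NC(=O)Cn1nnc2ccccc2c1=O)c1ccc(Cl)cc1` gives < 9.9 mL/min/kg, which is a limit of the assay and not a number. Compound 2 `C[C@H](NC(=O)Cn1nnc2ccccc2c1=O)c1ccc(Cl)cc1` gives < 9.9 mL/min/kg, again a limit. Between these two lies a step that the two limits leave unreadable from compound 1 to compound 2, so this pair offers no guidance on size. Going by the values given here, compound 3 `COc1ccc([C@H](C)NC(=O)Cn2nnc3ccccc3c2=O)cc1` gives 13 mL/min/kg, the only true number of the three, so it has no measured neighbour to be ranked against.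

The next compound is compound 4 `C[C@H](NC(=O)Cn1nnc2ccccc2c1=O)c1ccc(Br)cc1`, with bromo in place of methoxy on an aromatic carbon. Among the compounds with values here, the one measured step that touches this position is an at least 1.3-fold higher number from compound 2 to compound 3 (0.11 log units; that floor lies within the scatter), where methoxy took the place of chloro, and its floor lies within the scatter. Within the data shown here, that step is the only guide, and it gives no firm size. The estimated change is a 1.4-fold lower number from compound 3 to compound 4 (0.14 log units; within the scatter), a small drop that is expected to stay within the scatter. For compound 4 the expected clearance is 9.5 mL/min/kg, with an estimated range of 5 mL/min/kg to 16 mL/min/kg.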

Compound 4, clearance: < 9.9 mL/min/kg
Compound 4: only a limit was reported; the forecaster's own chance of this, stated with the estimate: 55%; the middle value lies beyond the limit too.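

In this assay, bromo in place of methoxy on the aromatic carbon para to a large group gives an at least 1.3-fold lower number from compound 3 to compound 4 (0.11 log units; that floor lies within the scatter), which mirrors the earlier change from chloro to methoxy, and neither step fixes a firm size. Compound 4 gives < 9.9 mL/min/kg, which is a limit of the assay and not a number, so the steps that have a limit at both ends, including the change from chloro to bromo, cannot be read. Any difference among the compounds that carry chloro or bromo therefore stays hidden: the limit of < 9.9 mL/min/kg in this assay, at which 3 of the 4 values shown sit.

Going by these compounds alone, compound 3 still holds the only true number, so how far clearance can move with the group at this position remains open. Also open, on these data alone, is whether an amine or a carboxylic acid at this place would give a true number that could be set against that of compound 3.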